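Removing the trifluoromethyl group: an expected loss

This account rests on a few compounds, and the source may have more. Where it says the series, first, only, none or still open, it means among the compounds named here.

Compound 3 `O=S(=O)(NCCNc1nccc(-c2c(-c3cccc(F)c3)nc3sccn23)n1)c1ccc(C(F)(F)F)cc1` is measured in a functional assay on SK-MEL-28 cells (Homo sapiens) for cytotoxicity, read by MTT assay (a higher number here means a weaker inhibitor, a lower number a stronger inhibitor), where compound 3 gives 8450 nM. Compound 2 `O=S(=O)(NCCCNc1nccc(-c2c(-c3cccc(F)c3)nc3sccn23)n1)c1ccc(Cl)cc1` gives 8450 nM, and compound 1 `O=S(=O)(NCCNc1nccc(-c2c(-c3cccc(F)c3)nc3sccn23)n1)c1ccc(Cl)cc1` gives 18600 nM. Compound 3 thus stands level with compound 2 at the digits shown, the two sharing the lowest number of the three, while compound 1 stands furthest away, separated by a 2.2-fold lower number from compound 1 to compound 3 (0.34 log units; beyond the scatter).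

Compound 4 `O=S(=O)(NCCNc1nccc(-c2c(-c3cccc(F)c3)nc3sccn23)n1)c1ccccc1` differs from compound 3 by hydrogen in place of trifluoromethyl on an aromatic carbon. For the measured compounds named here, no measured pair removes this group completely, but one measured step touches the same carbon: a 2.2-fold lower number from compound 1 to compound 3 (0.34 log units; beyond the scatter), where trifluoromethyl replaced chloro and the number fell. Going the other way, to hydrogen with no heavy atom at all, is expected to undo that gain and perhaps more, so a modest rise in the number is expected: a 2.1-fold higher number from compound 3 to compound 4 (0.33 log units; beyond the scatter). Compound 4 is therefore estimated at about 18000 nM, with a likely range from 8000 nM to 45000 nM.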

Compound 4, half-maximal inhibitory concentration: 19000 nM
Beside the measured number, compound 4's estimate is 1.1-fold (0.02 log units) below it, and the stated range covers the measured number.
By their numbers in this assay, from the lowest: compounds 2 and 3 (each within the scatter of the next); then compounds 1 and 4 (each within the scatter of the next).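

In this assay, hydrogen in place of trifluoromethyl on this aromatic carbon gives a 2.2-fold higher number from compound 3 to compound 4 (0.35 log units; beyond the scatter), whereas hydrogen in place of chloro on the same carbon gives a 1.0-fold higher number from compound 1 to compound 4 (0.01 log units; within the scatter) and stays within the scatter. Chloro and hydrogen therefore cannot be told apart here, and of the three groups only trifluoromethyl gives a lower number, which could not be seen before a compound with hydrogen at this carbon was available. The step of a 2.2-fold higher number from compound 2 to compound 4 (0.35 log units; beyond the scatter) carries the chain and the ring change together, so it does not separate the two.

As far as these compounds go, whether a methoxy group or a nitrile on this carbon would read like trifluoromethyl or like hydrogen remains open. Nothing available explains why trifluoromethyl stands apart from chloro and hydrogen.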